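Trading Isopropyl for Methyl on a Shared Core

A few compounds are considered here, and "the series" means these few. Any claim that something is new, unique, unknown or untested is made for them only; others in the source may bear on it.

Three compounds share one core and differ only in the groups on the aromatic ring. Compound 1 `CC(C)Oc1ccccc1OC(C)C1=NCCN1` carries an isopropoxy group and, in an assay on CHO cells for displacement of a labelled ligand from Alpha-2C adrenergic receptor (Homo sapiens) (on this read-out higher numbers stand for weaker inhibition and lower numbers for stronger inhibition), gives 398 nM, the highest of the three numbers. Compound 2 `Cc1cccc(C)c1OC(C)C1=NCCN1` gives 251 nM, which sits within the scatter of compound 1. Compound 3 `C=CCc1cccc(CC=C)c1OC(C)C1=NCCN1` gives 129 nM, a number that lies beyond the scatter below compound 1.

Compound 4 `COc1ccccc1OC(C)C1=NCCN1` is the next member. Relative to compound 1 the difference is methyl in place of isopropyl on an oxygen on an aromatic ring, so the group on that oxygen shrinks from three carbons to one. For the measured compounds named here, no measured pair shows this particular change, and the three numbers so far give no firm rule for it, since compound 2 and compound 3 alter other positions. A modest step toward a higher number, possibly still inside the scatter, is expected for compound 4 in this assay, as a 1.4-fold higher number from compound 1 to compound 4 (0.15 log units; within the scatter). Compound 4 is thus estimated at 560 nM, within 200 nM to 1600 nM.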

Compound 4, inhibition constant: 832 nM
Compound 4: the middle estimate sits 1.5-fold (0.17 log units) below what was measured; measured number inside the range.
By their numbers in this assay, from the lowest: compounds 3, 2 and 1 (each within the scatter of the next, the first and the last beyond it); then compound 4.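

In this assay, for the compounds shown here, methyl in place of isopropyl on an oxygen on an aromatic ring gives a 2.1-fold higher number from compound 1 to compound 4 (0.32 log units; beyond the scatter) and this is the first pair here that differs in one place only. Going by these compounds alone, it gives this oxygen a direction that the earlier compounds could not: the smaller group goes with weaker inhibition, by a modest step that lies beyond the usual scatter. No measurement shown here accounts for the step.

A single pair cannot show whether inhibition strengthens steadily as the group on this oxygen grows, and an ethyl group or a longer chain in that place would be needed to tell. Going by these compounds, whether a chain ending in a hydroxyl group or an amine would follow the same direction also remains open.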